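Amide Variants on the Acrylate Tail and Cytotoxicity

A few compounds are considered here, and "the series" means these few. Any claim that something is new, unique, unknown or untested is made for them only; others in the source may bear on it.

Compound 1, `CCOC(=O)/C=C/c1cnc(Nc2ccc(C#N)cc2)nc1Oc1c(C)cc(C#N)cc1C`, gives a limit of > 227 nM in an ADME assay on TZM cells (Homo sapiens) for cytotoxicity, with a stated time of 1 days; on this read-out higher numbers stand for lower toxicity in this test and lower numbers for higher toxicity in this test.
Compound 2, `Cc1cc(C#N)cc(C)c1Oc1nc(Nc2ccc(C#N)cc2)ncc1/C=C/C(=O)NC1CCN(S(C)(=O)=O)CC1`, gives a limit of > 175 nM in this assay.
Compound 3, `Cc1cc(C#N)cc(C)c1Oc1nc(Nc2ccc(C#N)cc2)ncc1/C=C/C(=O)NCC1CCN(S(C)(=O)=O)CC1`, gives a limit of > 171 nM in this assay.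

Compound 3 thus stands at a limit, and the other two values shown are limits as well. The steps a step that the two limits leave unreadable from compound 1 to compound 3 and a step that the two limits leave unreadable from compound 2 to compound 3 are therefore unreadable, as is a step that the two limits leave unreadable from compound 1 to compound 2. Compound 4, `Cc1cc(C#N)cc(C)c1Oc1nc(Nc2ccc(C#N)cc2)ncc1/C=C/C(=O)N1CCN(S(C)(=O)=O)CC1`, differs from compound 3 by 4-(methylsulfonyl)piperazin-1-yl in place of ((1-(methylsulfonyl)piperidin-4-yl)methyl)amino on a carbonyl carbon. With every neighbouring step unreadable, no direction can be expected in this assay beyond the scatter, and compound 4 is most likely to return another limit. The estimated step that the limit leaves unreadable from compound 3 to compound 4 is taken as none. Compound 4 is estimated at 230 nM, with a range from 150 nM to 600 nM.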

Compound 4, half-maximal cytotoxic concentration: > 179 nM
Compound 4: no number, only a limit (the forecaster's own chance of this, stated with the estimate: 80%); the middle value does not contradict the limit.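

Compound 4, like compound 1, compound 2 and compound 3, returns only a limit in this assay, so no step among these four compounds can be read. The compounds shown leave open how far any of these amide or ester tails separates in cytotoxicity, since no actual number is available.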